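Swapping the pyridine ring on a weak growth inhibitor

A few compounds are considered here, and "the series" means these few. Any claim that something is new, unique, unknown or untested is made for them only; others in the source may bear on it.

Of the compounds shown here, three sharing a trifluoromethyl-benzamide anilide core have been tested in an ADME assay on BaF3 cells (Mus musculus) for antiproliferative activity; a lower number here means a stronger inhibitor of growth, a higher number a weaker inhibitor of growth. Compound 1 `Cc1ccc(NC(=O)c2cccc(C(F)(F)F)c2)cc1OCCNC(=O)c1cccnc1` gives only a limit, > 10000 nM. Compound 2 `Cc1ccc(NC(=O)c2cccc(C(F)(F)F)c2)cc1OC1CCN(C(=O)c2ccncc2)CC1` likewise stops at a limit, > 10000 nM. For the measured compounds named here, compound 3 `O=C(Nc1cccc(OC2CCCN(C(=O)c3cccnc3)C2)c1)c1cccc(C(F)(F)F)c1` is the one compound with a number, 8070 nM, and so it stands as the only quantified member of the set. The other two rest at the limit of > 10000 nM in this assay, at which 2 of the 3 values shown sit.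

Compound 4 `O=C(Nc1cccc(OC2CCCN(C(=O)c3ccno3)C2)c1)c1cccc(C(F)(F)F)c1` has not yet been tested. It differs from compound 3 in one place: 1,2-oxazol-5-yl in place of pyridin-3-yl on a carbonyl carbon whose other neighbours are an amide-type nitrogen in a ring. Going by the values given here, no step between measured compounds is available for comparison, and nothing in the data assigns any effect to this exchange. With compound 3 already a weak inhibitor, a modest shift in either direction could leave compound 4 reported as a limit rather than a number. The expectation for this assay is a step of no more than the usual scatter, a 1.1-fold higher number from compound 3 to compound 4 (0.05 log units; within the scatter). Compound 4 is estimated at 9000 nM, within 3000 nM and 30000 nM, with a real chance that only a limit is recorded.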

Compound 4, concentration for 50% growth inhibition: > 10000 nM
Compound 4: a limit, no number; the forecaster's own chance of this, stated with the estimate: 45%; middle value at least 1.1-fold (0.04 log units) away from the limit.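

In this assay, the exchange of pyridin-3-yl for 1,2-oxazol-5-yl on this carbonyl carbon gives an at least 1.2-fold higher number from compound 3 to compound 4 (0.09 log units; that floor lies within the scatter), the first comparison the set allows at any position. Because that step has only a floor, and the floor lies within the scatter, it does not separate the two compounds, and the true size of the change cannot be read from it. Compound 4 gives a limit and not a number, which leaves compound 3 as the only quantified member of the set: the limit of > 10000 nM in this assay, at which 3 of the 4 values shown sit.

What the pair does establish is narrower: this five-membered ring, with its two hetero atoms and two hydrogen-bond acceptors, did not produce a lower number at this position. Still open, from the compounds shown here alone, is whether a plain phenyl ring, a 1,3-thiazol-5-yl ring or an aminomethyl group on the same carbonyl carbon would bring a lower number in this assay, and whether any such group would move the series clear of the limit.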